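Tosyl-indole sulfonamide series: benzyl variation on the triazole arm

The source may hold more compounds than are shown below. What is called first, only, known or untested is meant among the compounds shown, and "the series" means these compounds.

Measured compounds:
compound 1 `Cc1ccc(S(=O)(=O)N(Cc2cn(Cc3ccccc3Cl)nn2)Cc2cn(S(=O)(=O)c3ccc(C)cc3)c3ccccc23)cc1`, -4.8%
compound 2 `Cc1ccc(S(=O)(=O)n2cc(CN(Cc3cccc(F)c3F)C(=O)C(F)(F)F)c3ccccc32)cc1`, -5.5%

Both measured compounds were tested in a functional assay on 3T3-L1 cells (Mus musculus) for inhibition, with a stated time of 20 min, tested at 20 uM; on this read-out higher numbers stand for more inhibition at the one concentration tested (going by the name of the read-out) and lower numbers for less inhibition. Compound 1 gives -4.8%; compound 2 gives -5.5%. On these two numbers compound 1 and compound 2 sit within the scatter of each other, so neither stands apart, and both readings amount to no measurable inhibition at the concentration tested.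

The next compound, compound 3 `Cc1ccc(S(=O)(=O)N(Cc2cn(Cc3cccc(F)c3F)nn2)Cc2cn(S(=O)(=O)c3ccc(C)cc3)c3ccccc23)cc1`, has not yet been run in this assay. Relative to compound 1 the change is 2,3-difluorophenyl in place of 2-chlorophenyl on a saturated chain carbon bound to an aromatic nitrogen. Compound 2 carries the 2,3-difluorobenzyl group on a different core, and its reading is also flat in this assay.

Within the data shown here, with no step between measured compounds available, the step from compound 1 to compound 3 is expected to be none beyond the scatter: the estimate is a number 0.8 percentage points higher from compound 1 to compound 3 (within the scatter). Compound 3 is therefore expected to read -4% in this assay, with a range from -15% to 10%.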

Compound 3, a percentage reported as inhibition, at one concentration (the size of the read-out at that concentration, not a potency): 71.5%
Compound 3: the middle estimate sits 75.5 percentage points below what was measured; the measured number lies above the stated range.
By their numbers in this assay, from the lowest: compounds 2 and 1 (each within the scatter of the next); then compound 3.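

In this assay, exchanging 2-chlorobenzyl for 2,3-difluorobenzyl gives a number 76.3 percentage points higher from compound 1 to compound 3 (beyond the scatter) with the rest of the structure unchanged. Among these compounds, this is the first evidence that the aryl group on a saturated chain carbon bound to an aromatic nitrogen matters: the two earlier readings were flat and offered no step, while this single exchange separates a compound without measurable inhibition from one with clear inhibition at the one concentration tested. Nothing in the data accounts for the size of this step, and no measurement of any property of the two groups accompanies it.

The step rests on one pair of compounds and one concentration, so it does not show whether the gain follows from the loss of the chlorine, from either fluorine alone or from the two fluorines together, nor does it give a potency. Unsubstituted benzyl, 2-fluorobenzyl, 3-fluorobenzyl and 2,3-dichlorobenzyl at this position would begin to separate these readings, and a methoxy group on the same ring would test whether the effect extends beyond halogens.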